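Swapping the Group on an Amine Nitrogen

This account rests on a few compounds, and the source may have more. Where it says the series, first, only, none or still open, it means among the compounds named here.

Compound 1 `C=CC(=O)NCCOc1ccc(Oc2c(-c3ccc(F)cc3)sc3cc(O)ccc23)cc1`: > 25000 nM
Compound 2 `C=C(C)C(=O)N1CC(Oc2ccc(Oc3c(-c4ccc(F)cc4)sc4cc(O)ccc34)cc2)C1`: 14200 nM

In a functional assay on Ishikawa cells (Homo sapiens) for antiproliferative activity, read by CCK-8 assay, with a stated time of 48 h (on this read-out higher numbers stand for weaker inhibition and lower numbers for stronger inhibition), compound 1 gives > 25000 nM, which is a limit and not a number.

Compound 3 `O=C(/C=C/CNCCOc1ccc(Oc2c(-c3ccc(F)cc3)sc3cc(O)ccc23)cc1)N1CCCCC1` carries a new group on the amine nitrogen: 3-((piperidin-1-yl)carbonyl)prop-2-en-1-yl in place of vinylcarbonyl on an amine nitrogen.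

For the measured compounds named here, the one measured step, an at least 1.7-fold lower number from compound 1 to compound 2 (0.24 log units; that floor lies within the scatter), involves a different change, so it offers only weak guidance. Still, compound 2 reaches a true number at 14200 nM, so a modest move towards stronger inhibition is expected here too.

The expected step is an at least 2.5-fold lower number from compound 1 to compound 3 (0.39 log units; beyond the scatter).

Compound 3 is estimated at 10000 nM, with an expected range of 2500 nM to 25000 nM.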

Compound 3, half-maximal inhibitory concentration: 8430 nM
The estimate for compound 3 lay 1.2-fold (0.07 log units) above the measured number, within the range that was stated.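

Replacing vinylcarbonyl on the amine nitrogen with 3-((piperidin-1-yl)carbonyl)prop-2-en-1-yl gives an at least 2.9-fold lower number from compound 1 to compound 3 (0.47 log units; beyond the scatter) in this assay and is the first step shown that clears the scatter. This position therefore accepts a bigger group carrying a six-membered non-aromatic ring, without loss of activity. On these data alone, the true size of the step remains unknown, because compound 1 has only a limit: the limit of > 25000 nM in this assay, at which 1 of the 3 values shown sits.

The compounds shown leave open whether the piperidine ring itself matters. A morpholine or a dimethylamine in its place could settle that.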